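Methyl on the Core of Two Amide Inhibitors

The compounds below may be only part of what the source reports. "The series", "measured", "known", "first", "only" and "open" are said of these compounds alone.

Compound 1 `Cc1ccc2nc(-c3cccc(NC(=O)CCc4ccccc4)c3)[nH]c2c1`: in an assay on cells for inhibition of matrix metalloproteinase-9 (Homo sapiens), read by fluorescence, with stated times of 15 min and 4 h (on this read-out lower numbers stand for stronger inhibition and higher numbers for weaker inhibition), compound 1 gives 26600 nM
Compound 2 `O=C(CCc1ccccc1)Nc1cccc(-c2nc3ccccc3[nH]2)c1`: in this assay compound 2 gives 68000 nM
Compound 3 `O=C(CCc1ccccc1)Nc1ccc(-c2nc3ccccc3[nH]2)cc1`: in this assay compound 3 gives 29000 nM

Compound 2 and compound 3 are built from the same atoms joined differently; how their two cores differ is not broken down here. Compound 3 and compound 1 give numbers within the usual scatter of each other, while compound 2 and compound 3 stand beyond it. Compound 1 differs from compound 2 by methyl in place of hydrogen on an aromatic carbon, and this change gives a 2.6-fold lower number from compound 2 to compound 1 (0.41 log units; beyond the scatter).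

Compound 4 `Cc1ccc2nc(-c3ccc(NC(=O)CCc4ccccc4)cc3)[nH]c2c1` has not yet been measured in this assay. It differs from compound 3 by methyl in place of hydrogen on an aromatic carbon, the same change as that made from compound 2 to compound 1, at a place described in the same words. The expectation rests on the size of a 2.6-fold lower number from compound 2 to compound 1 (0.41 log units; beyond the scatter), assuming the change acts alike on the core of compound 3. For compound 4 the step is expected to be a 2.6-fold lower number from compound 3 to compound 4 (0.42 log units; beyond the scatter). Compound 4 is thus estimated to give about 11000 nM, with a likely range from 5000 nM to 30000 nM.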

Compound 4, half-maximal inhibitory concentration: 60000 nM
Compound 4: middle estimate off by 5.5-fold (0.74 log units), on the low side; measured number outside the range, above it.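

The same methyl change did not carry over from one core to the other. In this assay it now gives a 2.1-fold higher number from compound 3 to compound 4 (0.32 log units; beyond the scatter) and so runs opposite to the earlier step on the core of compound 2. This shows that, within these two pairs, neither the size nor the direction of the step can be taken from one core and applied to the other, but two pairs cannot show why they part ways or how the change would behave on a further core, and the two steps differ by more than repeated measurements would explain: the same change on two cores in this assay, a 2.6-fold lower number (0.41 log units; beyond the scatter) from compound 2 to compound 1 and a 2.1-fold higher number (0.32 log units; beyond the scatter) from compound 3 to compound 4, 5.3-fold (0.72 log units) apart, beyond the scatter of two such steps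

The compounds shown carry only hydrogen or methyl at this place, so it remains open whether a chlorine, a methoxy group or an ethyl group there would also split between the two cores. Going by these compounds, it also remains open whether a methyl group placed elsewhere on these cores would behave alike on both.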